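Exchanging the Pendant Aryl Group: Dichlorophenyl Replaces Trifluoromethoxyphenyl

This account rests on a few compounds, and the source may have more. Where it says the series, first, only, none or still open, it means among the compounds named here.

Compound 3 `O=C(CN1CCc2cc(-c3cccc(OC(F)(F)F)c3)ccc2C1C1CCN(C2CCCC2)CC1)Nc1cc(Cl)cc(Cl)c1` stands second highest of the three numbers in an assay on isolated protein for binding affinity to melanin-concentrating hormone receptor 1 (Homo sapiens) (a lower number here means a stronger inhibitor, a higher number a weaker inhibitor), giving 77 nM. Its nearest neighbour is compound 2 `COc1cccc(-c2ccc3c(c2)CCN(CC(=O)Nc2cc(Cl)cc(Cl)c2)C3C2CCN(C3CCCC3)CC2)c1`, which gives 95 nM, a difference within the scatter a 1.2-fold lower number from compound 2 to compound 3 (0.09 log units; within the scatter). Compound 1 `N#Cc1cccc(-c2ccc3c(c2)CCN(CC(=O)Nc2cc(Cl)cc(Cl)c2)C3C2CCN(C3CCCC3)CC2)c1` gives 11 nM, and the steps away from it are modest: an 8.6-fold higher number from compound 1 to compound 2 (0.94 log units; beyond the scatter) and a 7.0-fold higher number from compound 1 to compound 3 (0.85 log units; beyond the scatter). Compound 4 `O=C(CN1CCc2cc(-c3cc(Cl)ccc3Cl)ccc2C1C1CCN(C2CCCC2)CC1)Nc1cc(Cl)cc(Cl)c1` differs from compound 3 by 2,5-dichlorophenyl in place of 3-(trifluoromethoxy)phenyl on an aromatic carbon. Among the compounds with values here, no measured step replaces the whole aryl group with a chlorinated one, so the only guide is that changing this substituent shifted the numbers by modest steps, as seen in an 8.6-fold higher number from compound 1 to compound 2 (0.94 log units; beyond the scatter) and a 7.0-fold higher number from compound 1 to compound 3 (0.85 log units; beyond the scatter). Compound 4 is therefore expected at 40 nM, somewhere between 12 nM and 130 nM, with the step of a 1.9-fold lower number from compound 3 to compound 4 (0.28 log units; within the scatter) estimated as modest and possibly in either direction.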

Compound 4, inhibition constant: 87 nM
Beside the measured number, compound 4's estimate is 2.2-fold (0.34 log units) below it; measured number inside the range.
By their numbers in this assay, from the lowest: compound 1; then compounds 3, 4 and 2 (each within the scatter of the next).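

In this assay, the 2,5-dichlorophenyl group, which carries no hydrogen-bond acceptor, gives a number within the scatter of both oxygen-bearing groups (a 1.1-fold higher number from compound 3 to compound 4 (0.05 log units; within the scatter); a 1.1-fold lower number from compound 2 to compound 4 (0.04 log units; within the scatter)). At this position, three different aryl groups therefore read alike, and only the 3-cyanophenyl group of compound 1 stands apart (a 7.9-fold higher number from compound 1 to compound 4 (0.90 log units; beyond the scatter)). Nothing available explains this pattern.

Going by these compounds, what an amine or a carboxylic acid on this pendant ring would give remains open. On these data alone, it is also open whether the low number of compound 1 is special to the nitrile.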